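This account rests on a few compounds, and the source may have more. Where it says the series, first, only, none or still open, it means among the compounds named here.

Compound 1 `COc1ccc(S(=O)(=O)N2CCc3cccc(-c4ccc(N)cc4)c32)cc1` is the reference point of this small set. In a functional assay on KB-VIN10 cells (Homo sapiens) for inhibition, with a stated time of 72 h (on this read-out higher numbers stand for weaker inhibition and lower numbers for stronger inhibition), compound 1 gives 262 nM, the highest of the three numbers recorded so far. Compound 2 `COc1ccc(S(=O)(=O)N2CCc3cccc(-c4ccc([N+](=O)[O-])cc4)c32)cc1` gives 51.3 nM in this assay, and compound 3 `COc1ccc(S(=O)(=O)N2CCc3cccc(-c4cccc(F)c4)c32)cc1` gives 92.4 nM in this assay. Both measured steps away from compound 1 lower the number: a 5.1-fold lower number from compound 1 to compound 2 (0.71 log units; beyond the scatter) and a 2.8-fold lower number from compound 1 to compound 3 (0.45 log units; beyond the scatter). Between the two, a 1.8-fold higher number from compound 2 to compound 3 (0.26 log units; within the scatter).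

Compound 4 `COc1ccc(S(=O)(=O)N2CCc3cccc(-c4cccnc4)c32)cc1` is still to be measured in this assay. Relative to compound 1 the change is pyridin-3-yl in place of 4-aminophenyl on an aromatic carbon. Going by the values given here, both measured steps from compound 1 replace the 4-aminophenyl with a group lacking the hydrogen-bond donor, and both lower the number beyond the scatter, so a modest lowering is expected for compound 4 as well, though no measured step reproduces this exact change and the size is uncertain. Compound 4 is therefore expected to give 110 nM in this assay, with a range from 40 nM to 300 nM. The expected step is a 2.4-fold lower number from compound 1 to compound 4 (0.38 log units; beyond the scatter).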

Compound 4, half-maximal inhibitory concentration: 84.5 nM
Beside the measured number, compound 4's estimate is 1.3-fold (0.11 log units) above it; the range from low to high includes it.
By their numbers in this assay, from the lowest: compounds 2, 4 and 3 (each within the scatter of the next); then compound 1.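

In this assay, the pyridin-3-yl group on this aromatic carbon of the shared core behaves like a third replacement for the 4-aminophenyl group, with a 3.1-fold lower number from compound 1 to compound 4 (0.49 log units; beyond the scatter) as the step away from the reference. It shows no separation from the 3-fluorophenyl group, with a 1.1-fold lower number from compound 3 to compound 4 (0.04 log units; within the scatter) as the step, or from the 4-nitrophenyl group, with a 1.6-fold higher number from compound 2 to compound 4 (0.22 log units; within the scatter) as the step, so a ring with a hetero atom fits here as well as both substituted phenyl rings, and among the four compounds only compound 1 stands apart. No measurement at hand explains this grouping.

Still open, on these data alone, is whether the gap to compound 1 follows the amine itself or its place on the ring, which a 3-aminophenyl or 4-hydroxyphenyl group would test. Also open, as far as these compounds go, is how a pyridin-4-yl group or a saturated piperidine ring would compare at this carbon.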